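Benzyl variation on the shared core: compound 2 to compound 4

The source may report more compounds than this note shows. Statements on the series, on what has been measured and on what is new or still open speak of the compounds shown alone.

Compound 2 `COc1cccc(CNc2ncnc3c2ncn3[C@@H]2O[C@H](CO)[C@@H](O)[C@H]2O)c1` is the point of departure. In a functional assay on MCF cells (Homo sapiens) for antiproliferative activity, with a stated time of 72 h (on this read-out lower numbers stand for stronger inhibition and higher numbers for weaker inhibition), compound 2 gives > 166000 nM, which is a limit of the assay and not a number. The other two measured compounds sit in the same place. Compound 1 `OC[C@H]1O[C@@H](n2cnc3c(NCc4ccc(Br)cc4)ncnc32)[C@H](O)[C@@H]1O` gives > 166000 nM in this assay, again a limit. Compound 3 `OC[C@H]1O[C@@H](n2cnc3c(NCc4cc(F)cc(F)c4)ncnc32)C(O)C1O` gives > 166000 nM in this assay, also a limit. the limit of > 166000 nM in this assay, at which 3 of the 3 values shown sit, sums this up: every value shown so far is the same limit, so compound 2 cannot be placed above or below any other member of the series on the numbers available.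

Compound 4 `OC[C@H]1O[C@@H](n2cnc3c(NCc4ccc(F)cc4Cl)ncnc32)[C@H](O)[C@@H]1O` has not been measured. It differs from compound 2 in one place: 2-chloro-4-fluorophenyl in place of 3-methoxyphenyl on a saturated chain carbon bound to a nitrogen on an aromatic ring.

Within the data shown here, only one measured step is of a comparable kind, a change of the group on the saturated chain carbon bound to a nitrogen on an aromatic ring: a step that the two limits leave unreadable from compound 1 to compound 2. Its size is not readable, so it gives neither direction nor size to carry over. Compound 1 and compound 3 are not linked by a single step, and each shows only the limit.

With no readable step in hand, compound 4 is expected to come out as the others did, most likely at the limit rather than as a number. The estimate for compound 4 in this assay is 200000 nM with a range from 40000 nM to 1000000 nM. This means an expected step that the limit leaves unreadable from compound 2 to compound 4, not readable against the limit.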

Compound 4, half-maximal inhibitory concentration: > 166000 nM
Compound 4 ended at the assay's limit; the forecaster's own chance of this, stated with the estimate: 85%; the middle value is on the limit's open side.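

In this assay compound 4 gives > 166000 nM, a limit and not a number. Among these compounds, the steps to compound 4 from compound 1 and from compound 2 cannot be read, so no new step comes from this result: the limit of > 166000 nM in this assay, at which 4 of the 4 values shown sit. The compounds shown leave open whether any benzyl group on the shared core gives a measurable value in this assay.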